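Swapping 2-methoxyphenyl for 4-methoxyphenyl at the chain end

The source may hold more compounds than are shown below. What is called first, only, known or untested is meant among the compounds shown, and "the series" means these compounds.

In a functional assay on HCT-116 cells (Homo sapiens) for inhibition, read by sulforhodamine B assay, with a stated time of 48 h, tested at 50 uM (on this read-out lower numbers stand for less inhibition of growth and higher numbers for more inhibition of growth at the one concentration tested), compound 3 `COc1ccccc1/C=C/C(=O)/C=C/c1ccc(OCc2cn(CCOc3cc(=O)oc4ccccc34)nn2)c(OC)c1` gives 70%. Two relatives share its core and differ only in the group at one end of the chain: compound 1 `COc1cc(/C=C/C(=O)/C=C/c2cccs2)ccc1OCc1cn(CCOc2cc(=O)oc3ccccc23)nn1` gives 71%, and compound 2 `COc1cc(/C=C/C(=O)/C=C/c2ccco2)ccc1OCc1cn(CCOc2cc(=O)oc3ccccc23)nn1` gives 72%. All three values lie within the scatter of one another, so compound 3 cannot be ranked against the other two.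

Compound 4 `COc1ccc(/C=C/C(=O)/C=C/c2ccc(OCc3cn(CCOc4cc(=O)oc5ccccc45)nn3)c(OC)c2)cc1` has not yet been measured. Its structure differs from that of compound 3 at that same chain end: 4-methoxyphenyl in place of 2-methoxyphenyl on a double-bonded chain carbon bound to a double-bonded chain carbon. Here 4-methoxyphenyl stands in place of 2-methoxyphenyl.

The measured steps at this place are a number 1 percentage points higher from compound 1 to compound 2 (within the scatter), a number 1 percentage points lower from compound 1 to compound 3 (within the scatter) and a number 2 percentage points lower from compound 2 to compound 3 (within the scatter). All are small, but none of them tests the 4-methoxyphenyl group itself, so they offer only indirect guidance. No step beyond the scatter is therefore expected in this assay.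

The expected change is a number 1 percentage points higher from compound 3 to compound 4 (within the scatter). The estimate for compound 4 is 71%, within an expected range of 61% to 80%.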

Compound 4, percent growth inhibition at one concentration: 71%
Estimate against measurement, compound 4: no gap at the digits printed; measured number inside the range.
By their numbers in this assay, from the lowest: compounds 3, 1, 4 and 2 (each within the scatter of the next).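

In this assay, exchanging 2-methoxyphenyl for 4-methoxyphenyl gives a number 1 percentage points higher from compound 3 to compound 4 (within the scatter), so this pair of groups, made of the same atoms joined differently, cannot be told apart at this place. Exchanging furan-2-yl for 4-methoxyphenyl gives a number 1 percentage points lower from compound 2 to compound 4 (within the scatter), and exchanging thiophen-2-yl for it gives no change at the digits printed from compound 1 to compound 4 (within the scatter), so all four groups at this chain end now lie within the scatter of one another. Nothing shown here bears on why these groups read alike.

Going by these compounds, it remains open whether a group of another kind at this place, such as an amine, a carboxylic acid or a longer alkyl chain, would read differently. A reading at one concentration also leaves open whether these four compounds would separate at lower concentrations.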